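A few compounds are considered here, and "the series" means these few. Any claim that something is new, unique, unknown or untested is made for them only; others in the source may bear on it.

Among the measured compounds shown here, in a functional assay on OVCAR-8 cells (Homo sapiens) for inhibition, read by sulforhodamine B assay, with a stated time of 48 h (a higher number here means a weaker inhibitor of growth, a lower number a stronger inhibitor of growth), compound 2 `COc1cc2cc(Oc3ccc(NC(=O)Nc4ccc(Cl)c(C(F)(F)F)c4)cc3)c(C)nc2cc1OC` gives 1040 nM, the lower of the two numbers measured so far; its nearest neighbour is compound 1 `COc1cc2cc(Oc3ccc(NC(=O)Nc4cccc(C(F)(F)F)c4)cc3)c(C)nc2cc1OC`, which gives 1710 nM in this assay, and the step of a 1.6-fold lower number from compound 1 to compound 2 (0.22 log units; within the scatter) stays within the scatter, so the two cannot be ranked. Compound 3 `COc1cc2cc(Oc3ccc(NC(=O)Nc4ccc(Cl)c(Cl)c4)cc3)c(C)nc2cc1OC` is reached from compound 2 by chloro in place of trifluoromethyl on an aromatic carbon, at the position described as ortho to a chloro group and meta to a large group. For the measured compounds named here, no measured step involves a change at this position, and the one measured step changed a different position by a small amount, so there is no direct guide. The expectation is a step in this assay of about a 1.4-fold higher number from compound 2 to compound 3 (0.16 log units; within the scatter), that is, little change beyond the scatter. Compound 3 is therefore estimated to give 1500 nM in this assay, with a likely range from 700 nM to 3500 nM.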

Compound 3, concentration for 50% growth inhibition: 3540 nM
The estimate for compound 3 lay 2.4-fold (0.37 log units) below the measured number, outside the stated range (above it).
By their numbers in this assay, from the lowest: compounds 2 and 1 (each within the scatter of the next); then compound 3.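

Trifluoromethyl and chloro are not interchangeable at this position, ortho to a chloro group and meta to a large group: in this assay the exchange gives a 3.4-fold higher number from compound 2 to compound 3 (0.53 log units; beyond the scatter) and so moves the number more than the earlier addition of chloro, which stayed within the scatter. The 3,4-dichlorophenyl compound also separates from the compound carrying 3-(trifluoromethyl)phenyl, with a 2.1-fold higher number from compound 1 to compound 3 (0.32 log units; beyond the scatter), so within these three compounds, the one without trifluoromethyl gives the highest number. Nothing available here offers a reason for this rise.

The compounds shown leave open how other groups at this position, such as a nitrile, a methoxy group or an amine, would compare with trifluoromethyl and chloro. They also leave open whether the same exchange would give a step of similar size on a ring without the neighbouring chloro group.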